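The source may report more compounds than this note shows. Statements on the series, on what has been measured and on what is new or still open speak of the compounds shown alone.

Measured in an assay on NK92 cells for inhibition of interleukin-2 (Homo sapiens), read by AlphaScreen, with stated times of 30 min and 1 h; a higher number here means a weaker inhibitor, a lower number a stronger inhibitor:
compound 1 `Cn1c(Cc2nn(C)c(=O)c3ccccc23)nnc1SCC(=O)Nc1ccc(Cl)cc1Cl` gives 7700 nM
compound 2 `Cn1nc(Cc2nnc(SCCCCCCCC(=O)Nc3ccc(Cl)cc3Cl)[nH]2)c2ccccc2c1=O` gives 450 nM
compound 3 `CN(C)CCCn1nc(Cc2nnc(SCCCCCCCC(=O)Nc3ccc(Cl)cc3Cl)n2C)c2ccccc2c1=O` gives > 30000 nM

For compound 3 the reading in this assay is a limit, not a number: it sits at the limit of > 30000 nM in this assay, at which 1 of the 3 values shown sits, so compound 3 stands at the top of the numbers shown. Compound 1 and compound 2 both give numbers in this assay, with compound 2 the lower of the two.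

Compound 4 `Cn1c(Cc2n[nH]c(=O)c3ccccc23)nnc1SCCCCCCCC(=O)Nc1ccc(Cl)cc1Cl` differs from compound 3 by hydrogen in place of 3-(dimethylamino)propyl on an aromatic nitrogen. Among the measured compounds shown here, no step between measured compounds covers this change; compound 2 carries the same long chain and amide and gives 450 nM in this assay. The step from compound 3 to compound 4 is expected to be downward, toward stronger inhibition, by an at least 20-fold lower number from compound 3 to compound 4 (1.30 log units; beyond the scatter), beyond the scatter. Compound 4 is estimated at 1500 nM, within 300 nM to 10000 nM.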

Compound 4, half-maximal inhibitory concentration: > 30000 nM
Compound 4 was reported as a limit (the forecaster's own chance of this, stated with the estimate: 15%); at least 20-fold (1.30 log units) between middle value and limit.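

In this assay compound 3 and compound 4 are both reported as limits, not numbers, so no step between them can be read: the limit of > 30000 nM in this assay, at which 2 of the 4 values shown sit.

Left open is what size of change, if any, hydrogen in place of 3-(dimethylamino)propyl on an aromatic nitrogen brings.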